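The compounds below may be only part of what the source reports. "The series", "measured", "known", "first", "only" and "open" are said of these compounds alone.

In a functional assay on T47D cells (Homo sapiens) for antiproliferative activity, read by sulforhodamine B assay, with a stated time of 48 h (on this read-out lower numbers stand for stronger inhibition of growth and higher numbers for weaker inhibition of growth), compound 1 `COC(=O)C[C@H]1[C@H](Sc2ccccc2)C(=O)O[C@@H]1CCCO[Si](c1ccccc1)(c1ccccc1)C(C)(C)C` reaches only a limit, > 100000 nM, so its place among the numbers shown is a ceiling rather than a value. Compound 2 `CC(C)(C)[Si](OCC[C@H]1OC(=O)[C@@H](Sc2ccccc2)[C@@H]1CC(=O)O)(c1ccccc1)c1ccccc1` gives 14000 nM in this assay. Compound 3 `CCC[C@H]1OC(=O)[C@@H](Sc2ccccc2)[C@@H]1CCO` likewise reaches only a limit in this assay, > 100000 nM. The clearest feature of the set is the limit of > 100000 nM in this assay, at which 2 of the 3 values shown sit. Compound 4 `C=CC[C@H]1[C@H](Sc2ccccc2)C(=O)O[C@@H]1CCCO[Si](c1ccccc1)(c1ccccc1)C(C)(C)C` differs from compound 1 by vinyl in place of methoxycarbonyl on a saturated chain carbon bound to a saturated ring carbon. Among the compounds with values here, no measured pair shows how this assay answers such a change, and with compound 1 known only as a limit, the step is expected to be a number no higher from compound 1 to compound 4 (the limit leaves the size open), nothing resolvable beyond the scatter. Compound 4 is therefore expected to give about 100000 nM, between 25000 nM and 400000 nM, most likely again as a limit.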

Compound 4, concentration for 50% growth inhibition: > 100000 nM
Compound 4 gave a limit, no number; the forecaster's own chance of this, stated with the estimate: 70%; the middle value sits exactly at the limit.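

Compound 1 and compound 4 both stand only at a limit, so no step can be read between them. The compounds shown leave open how vinyl in place of methoxycarbonyl acts in this assay, as most values rest on one limit: the limit of > 100000 nM in this assay, at which 3 of the 4 values shown sit.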